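The compounds below may be only part of what the source reports. "The series", "measured", "known", "first", "only" and "open" are said of these compounds alone.

Values in a physicochemical assay for solubility (on this read-out lower numbers stand for lower solubility and higher numbers for higher solubility), measured so far, each one a limit:
compound 1 `CNC(=O)c1cc(C(=O)NC2CC2)cn(Cc2cccc(F)c2)c1=O` gives >= 133 ug/mL as a limit
compound 2 `CNC(=O)c1cc(C(=O)NC2CCOCC2)cn(Cc2ccccc2)c1=O` gives >= 174 ug/mL as a limit
compound 3 `CNC(=O)c1cc(C(=O)NC2CC2)cn(CC2CCCCC2)c1=O` gives >= 148 ug/mL as a limit

The place of compound 2 is known only as a limit, given as >= 174 ug/mL and not as a number. The same holds for the other two compounds, so no order can be read among the three.

The step to follow leads to compound 4 `CNC(=O)c1cc(C(=O)NC)c(=O)n(Cc2ccccc2)c1`, not yet measured. The change is methyl in place of oxan-4-yl on an amide-type nitrogen, in words methyl in place of oxan-4-yl on an amide-type nitrogen.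

Among the compounds with values here, no measured step changes this place. Within the data shown here, the only step available is a step that the two limits leave unreadable from compound 1 to compound 3 and it concerns cyclohexyl in place of 3-fluorophenyl on a saturated chain carbon bound to an aromatic nitrogen. It gives no size to carry over, and no direction either.

In this assay no step beyond the scatter is therefore expected. This expectation starts from compound 2 and its value >= 174 ug/mL, which is a limit. The expected step is an at least 1.2-fold lower number from compound 2 to compound 4 (0.09 log units; that floor lies within the scatter) and it is only an estimate. For compound 4 the estimate is 140 ug/mL, with an expected range from 70 ug/mL to 220 ug/mL, and a report as a limit is also expected to be likely.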

Compound 4, solubility: >= 118 ug/mL
Compound 4 ended at the assay's limit (the forecaster's own chance of this, stated with the estimate: 70%); the middle value does not contradict the limit.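

In this assay compound 4 gives >= 118 ug/mL, which is a limit. Compound 2 is also known only as a limit, so no step can be read between compound 2 and compound 4. The compounds shown leave open whether methyl in place of oxan-4-yl on an amide-type nitrogen shifts this read-out at all, and in which direction.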